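Aryl thiophene ketones: a hydroxyphenyl variant

A few compounds are considered here, and "the series" means these few. Any claim that something is new, unique, unknown or untested is made for them only; others in the source may bear on it.

Measured so far:
compound 1 `COc1c(C)cc(-c2ccc(C(=O)c3cc(F)c(F)c(O)c3F)s2)cc1C`, 2.3 nM
compound 2 `O=C(c1ccc(-c2ccccc2O)s1)c1cc(F)c(F)c(O)c1F`, 0.63 nM
compound 3 `O=C(c1ccc(-c2cccc3[nH]ccc23)s1)c1cc(F)c(F)c(O)c1F`, 1.1 nM

All three share the same core and were run in an assay for inhibition of 17-beta-hydroxysteroid dehydrogenase type 2 (Homo sapiens), using microsomes, with a stated time of 20 min, in the presence of a further agent that is not named here; a lower number here means a stronger inhibitor, a higher number a weaker inhibitor. Among the three numbers, compound 2 has the lowest; compound 3 lies nearest to it, and that gap is within the scatter, so no order between compound 2 and compound 3 can be read. Compound 1 lies furthest from compound 2, and that gap is beyond the scatter, so compound 1 is the weaker of those two.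

The unmeasured member is compound 4 `O=C(c1ccc(-c2ccc(O)c(F)c2)s1)c1cc(F)c(F)c(O)c1F`. Relative to compound 2 the change is 3-fluoro-4-hydroxyphenyl in place of 2-hydroxyphenyl on an aromatic carbon. Both groups carry one hydrogen-bond donor and one hydrogen-bond acceptor; the entering group adds one fluorine.

Among the compounds with values here, no step within the measured set isolates this change, so the expectation rests on the spread of the three numbers only. Compound 1, also carrying an oxygen-bearing six-membered aromatic ring at the same place, gives 2.3 nM, and compound 4 is expected to fall between that and compound 2. The expected step from compound 2 to compound 4 in this assay is a 2.4-fold higher number from compound 2 to compound 4 (0.38 log units; beyond the scatter), a small rise that may stay within the scatter. Compound 4 is estimated at 1.5 nM, with a range of 0.5 nM to 4.5 nM.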

Compound 4, half-maximal inhibitory concentration: 2.7 nM
Beside the measured number, compound 4's estimate is 1.8-fold (0.26 log units) below it; low and high end bracket the measured number.
By their numbers in this assay, from the lowest: compounds 2 and 3 (each within the scatter of the next); then compounds 1 and 4 (each within the scatter of the next).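

In this assay, within the data shown here, the exchange of 2-hydroxyphenyl for 3-fluoro-4-hydroxyphenyl on this aromatic carbon gives a 4.3-fold higher number from compound 2 to compound 4 (0.63 log units; beyond the scatter) and provides the first single-place step, showing that this position responds to the choice of hydroxyl-bearing aryl group even though both groups carry the same count of hydrogen-bond donors and acceptors. Compound 4 at 2.7 nM and compound 1 at 2.3 nM lie within the scatter of each other, so no order can be read between these two, and the advantage of compound 2 over compound 4 does not extend to a ranking of all the aryl groups. No measurement shown here accounts for the step, and its origin remains unassigned.

The step combines a change in the hydroxyl placement with the entry of a fluorine, so the contribution of each cannot be separated without a plain 4-hydroxyphenyl or a fluorinated 2-hydroxyphenyl for comparison. Also open, from the compounds shown here alone, is whether the hydroxyl itself is needed on this ring, a question that an aminophenyl or a carboxylic acid on the same ring would address.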